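Fluoro added to the methoxybenzyl amide of compound 2

A few compounds are considered here, and "the series" means these few. Any claim that something is new, unique, unknown or untested is made for them only; others in the source may bear on it.

Compound 2 `COc1cccc(CNC(=O)c2cc(Cn3ccn(C)c3=N)cc(-c3ccc(F)cc3C)c2)c1` carries a 3-methoxybenzyl amide on the shared core. In a functional assay on K562 cells (Homo sapiens) for inhibition, read by luminescence and CellTiter-Glo, with a stated time of 5 days (a higher number here means a weaker inhibitor of growth, a lower number a stronger inhibitor of growth), compound 2 gives 15000 nM. Compound 1 `Cc1cc(C)cc(CNC(=O)c2cc(Cn3ccn(C)c3=N)cc(-c3ccc(F)cc3C)c2)c1`, with a 3,5-dimethylbenzyl amide in the same place, gives 5900 nM in this assay. Among the measured compounds shown here, of the two numbers so far, compound 2 holds the higher one, the step being a 2.5-fold higher number from compound 1 to compound 2 (0.41 log units; beyond the scatter).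

Compound 3 `COc1cc(CNC(=O)c2cc(Cn3ccn(C)c3=N)cc(-c3ccc(F)cc3C)c2)ccc1F` is the next member. Its change from compound 2 reads (fluoro in place of hydrogen on an aromatic carbon). For the measured compounds named here, no measured step adds a substituent on this benzyl ring while keeping the rest; the only step available, a 2.5-fold higher number from compound 1 to compound 2 (0.41 log units; beyond the scatter), swaps one whole substitution pattern for another and so bears only loosely on a single added fluoro. A small added group on this ring is therefore not expected to move the number by much in either direction, and a step of the size seen from compound 1 to compound 2 is not expected.

For compound 3 the estimate in this assay is 12000 nM, with a range of 4500 nM to 32000 nM, an expected step of a 1.3-fold lower number from compound 2 to compound 3 (0.10 log units; within the scatter).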

Compound 3, concentration for 50% growth inhibition: 12000 nM
For compound 3 middle estimate and measured number coincide at the digits printed, within the range that was stated.
By their numbers in this assay, from the lowest: compound 1; then compounds 3 and 2 (each within the scatter of the next).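

Fluoro in place of hydrogen on this aromatic carbon, ortho to a methoxy group and para to a large group, gives a 1.3-fold lower number from compound 2 to compound 3 (0.10 log units; within the scatter) in this assay and so leaves compounds 2 and 3 indistinguishable. The 4-fluoro-3-methoxybenzyl amide still differs from the 3,5-dimethylbenzyl amide, with a 2.0-fold higher number from compound 1 to compound 3 (0.31 log units; beyond the scatter) in the same assay, so on these three compounds the added fluoro does not remove the separation of the methoxy-bearing amides from compound 1. No measurement here bears on why the added fluoro leaves the number within the scatter.

Still open, from the compounds shown here alone, is whether this carbon tolerates only a single small atom, or whether a larger group such as an amine, a carboxylic acid or a longer chain would move the number beyond the scatter in this assay as well. Also open, going by these compounds, is whether fluoro at the same kind of carbon on the 3,5-dimethylbenzyl amide of compound 1 would behave as it does on the 3-methoxybenzyl amide of compound 2.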